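Swapping phenyl for pyridin-3-yl on two hydrazone cores

The compounds below may be only part of what the source reports. "The series", "measured", "known", "first", "only" and "open" are said of these compounds alone.

Of the compounds shown here, three have been tested in a functional assay on the whole organism (strain Wistar) for inhibition, with Rattus norvegicus as the target, read by paw edema, with a stated time of 30 min, at a dose of 10 mg/kg by the intraperitoneal route; a higher number here means more inhibition at the dose given (going by the name of the read-out), a lower number less inhibition. Compound 1 `O=C(N/N=C/c1ccccc1)c1cccnc1Nc1cccc(C(F)(F)F)c1` gives 60.4%, and compound 2 `O=C(N/N=C/c1cccnc1)c1cccnc1Nc1cccc(C(F)(F)F)c1` gives 59.1%. The change between them, (pyridin-3-yl in place of phenyl on a carbon with a double bond to nitrogen), made a step of a number 1.3 percentage points lower from compound 1 to compound 2 (within the scatter). Compound 3 `CNc1ncccc1C(=O)N/N=C/c1ccccc1` gives 56.5%, and its steps to compound 1 and compound 2 both lie within the scatter, so the three numbers cannot be put in order. The difference between the cores of compound 1 and compound 3 is not broken down here.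

Compound 4 `CNc1ncccc1C(=O)N/N=C/c1cccnc1` has not yet been measured. It differs from compound 3 by pyridin-3-yl in place of phenyl on a carbon with a double bond to nitrogen, the same change that was made from compound 1 to compound 2, and occurring twice in all among these compounds. Because that earlier change gave a step of a number 1.3 percentage points lower from compound 1 to compound 2 (within the scatter), the step from compound 3 to compound 4 in this assay is expected to be similar, estimated at a number 1.5 percentage points lower from compound 3 to compound 4 (within the scatter). Compound 4 is therefore expected to give about 55% in this assay, likely between 45% and 65%.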

Compound 4, a percentage reported as inhibition, in the whole organism at one dose (the size of the read-out at that dose, not a potency): 66.3%
Beside the measured number, compound 4's estimate is 11.3 percentage points below it; the whole stated range lies below it.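

The swap of phenyl for pyridin-3-yl gives a step in this assay of a number 9.8 percentage points higher from compound 3 to compound 4 (within the scatter), so it cannot be read as a real gain in inhibition, even though the number landed well away from the estimate. Set beside the earlier step, the same change on the other core gives no sign that the two cores respond differently: the same change on two cores in this assay, a number 1.3 percentage points lower (within the scatter) from compound 1 to compound 2 and a number 9.8 percentage points higher (within the scatter) from compound 3 to compound 4, 11.1 percentage points apart, within the scatter of two such steps. This shows that on these two cores the change leaves no readable mark on paw edema at this one dose, but it does not show that the change is without effect, that the two cores respond alike, or that the same would hold on any further core.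

Going by these compounds, all four compounds carry either phenyl or pyridin-3-yl on that carbon, so it remains open whether a ring bearing a carboxylic acid or an amine there would give a step beyond the scatter. On these data alone, it also remains open how the compounds would compare at other doses or times.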